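Swapping a Ring Amine for an Open-Chain Amine

This account rests on a few compounds, and the source may have more. Where it says the series, first, only, none or still open, it means among the compounds named here.

Measured so far in a functional assay on the whole organism for inhibition, with Cicer arietinum as the target, with a stated time of 7 days; a higher number here means a weaker inhibitor, a lower number a stronger inhibitor:
Compound 1 `S=C(SCc1nc2ccccc2[nH]1)N1CCOCC1` gives 1890 nM
Compound 2 `S=C(SCc1nc2ccccc2[nH]1)N1CCCCC1` gives 1660 nM

Compound 2 stands beside compound 1 rather than apart from it, since a 1.1-fold lower number from compound 1 to compound 2 (0.06 log units; within the scatter). Compound 3 `CCN(CC)C(=S)SCc1nc2ccccc2[nH]1` carries diethylamino in place of piperidin-1-yl on a thiocarbonyl carbon. Within the data shown here, the only earlier step that changed this same group, from compound 1 to compound 2, stayed within the scatter, so a further exchange of the amine attached to the thiocarbonyl carbon is expected to move the number little: a 1.0-fold higher number from compound 2 to compound 3 (0.01 log units; within the scatter). Compound 3 is therefore estimated at 1700 nM, with a range from 800 nM to 3600 nM.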

Compound 3, half-maximal inhibitory concentration: 1860 nM
Compound 3: middle estimate off by 1.1-fold (0.04 log units), on the low side, and the stated range covers the measured number.
By their numbers in this assay, from the lowest: compounds 2, 3 and 1 (each within the scatter of the next).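

Opening the ring does not register in this assay: the change to diethylamino gives a 1.1-fold higher number from compound 2 to compound 3 (0.05 log units; within the scatter), and the comparison with morpholin-4-yl gives a 1.0-fold lower number from compound 1 to compound 3 (0.01 log units; within the scatter). On the thiocarbonyl carbon, the two ring amines and this open-chain amine therefore all lie within the scatter of one another, so having a ring at this position makes no measurable difference among these compounds. Nothing available explains why these numbers stay so close.

On these data alone, whether an amine bearing a longer chain or a carboxylic acid would leave the number equally unmoved remains open.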